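The source may report more compounds than this note shows. Statements on the series, on what has been measured and on what is new or still open speak of the compounds shown alone.

Within the data shown here, in a physicochemical assay for solubility, with a stated time of 18 h, at pH 7.4 (on this read-out higher numbers stand for higher solubility and lower numbers for lower solubility), compound 3 (`COc1ccc(-c2ccc3c(NCCCNCc4cc(F)ccc4OC)ccnc3c2)cc1`) gives 32000 nM, the highest of the three numbers so far. Compound 1 (`COc1ccc(F)cc1CNCCCNc1ccnc2cc(Oc3ccc(F)cc3)ccc12`) gives 14500 nM. Compound 2 (`COc1ccc(F)cc1CNCCCNc1ccnc2cc(Cc3ccc(F)cc3Cl)ccc12`) gives 4200 nM. Compound 4 (`COc1ccc(F)cc1CNCCCNc1ccnc2cc(Oc3ccc(C(C)(C)C)cc3)ccc12`) is not yet measured. Its change from compound 3 is 4-(tert-butyl)phenoxy in place of 4-methoxyphenyl on an aromatic carbon.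

Among the measured compounds shown here, three measured steps bear on this change. Putting 4-methoxyphenyl in place of 4-fluorophenoxy gives a 2.2-fold higher number from compound 1 to compound 3 (0.34 log units; beyond the scatter). The 2-chloro-4-fluorobenzyl exchanges give a 3.5-fold lower number from compound 1 to compound 2 (0.54 log units; beyond the scatter) and a 7.6-fold higher number from compound 2 to compound 3 (0.88 log units; beyond the scatter). All three are modest and beyond the scatter. For the measured compounds named here, no measured compound carries 4-(tert-butyl)phenoxy, so the size of the step remains uncertain. Going by the values given here, compound 1, at 14500 nM, is the only measured compound with a phenoxy group at this place, so a lower number is expected in this assay, of a size like the largest measured step. The expected step is an 8.0-fold lower number from compound 3 to compound 4 (0.90 log units; beyond the scatter). For compound 4 the estimate is 4000 nM, with an expected range of 1000 nM to 12000 nM.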

Compound 4, solubility: 14500 nM
The estimate for compound 4 lay 3.6-fold (0.56 log units) below the measured number; measured number above the stated range.
By their numbers in this assay, from the lowest: compound 2; then compounds 1 and 4 (each within the scatter of the next); then compound 3.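

In this assay, tert-butyl in place of fluoro on the phenoxy group leaves the number level (no change at the digits printed from compound 1 to compound 4 (within the scatter)), so at this position the two phenoxy compounds cannot be told apart despite the change of that end group. Compound 4 repeats the standing of compound 1 against the other two groups, with 4-methoxyphenyl still ahead (a 2.2-fold lower number from compound 3 to compound 4 (0.34 log units; beyond the scatter)) and 2-chloro-4-fluorobenzyl still behind (a 3.5-fold higher number from compound 2 to compound 4 (0.54 log units; beyond the scatter)). Nothing available accounts for these numbers.

Open, from the compounds shown here alone, is whether the level result holds for a carboxylic acid or an amine in place of the tert-butyl on the phenoxy group. Also open, going by these compounds, is what 4-(tert-butyl)phenyl would give, which would separate the effect of the phenoxy oxygen from that of the end group.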